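This account rests on a few compounds, and the source may have more. Where it says the series, first, only, none or still open, it means among the compounds named here.

Compound 1 `ClCc1cccc(Cn2cnc3ncnc(Cl)c32)c1` was tested in a functional assay on HCT-15 cells (Homo sapiens) for cytotoxicity, read by sulforhodamine B assay, with a stated time of 48 h; a higher number here means that more compound is tolerated, a lower number that less compound is tolerated. There compound 1 gives > 100000 nM, which is a limit of the assay and not a number. For compound 1 the only thing known is therefore (the limit of > 100000 nM in this assay, at which 1 of the 2 values shown sits). Compound 2 `ClCc1ccc(Cn2cnc3nc(Cl)nc(Cl)c32)cc1` gives 6760 nM in this assay. Compound 3 `ClCc1cccc(Cn2cnc3nc(Cl)nc(Cl)c32)c1` differs from compound 1 by chloro in place of hydrogen on an aromatic carbon. For the measured compounds named here, no measured pair shows this change on its own, so the step is only an expectation: in this assay the number is expected to fall, by an estimated at least 8.3-fold lower number from compound 1 to compound 3 (0.92 log units; beyond the scatter). Compound 3 is expected to give 12000 nM, within 2500 nM to 60000 nM.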

Compound 3, concentration lethal to 50% of the cells: 4570 nM
Estimate against measurement, compound 3: 2.6-fold (0.42 log units) above, and the stated range covers the measured number.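

In this assay, chloro in place of hydrogen on this aromatic carbon, between two ring nitrogen atoms, gives an at least 21-fold lower number from compound 1 to compound 3 (1.34 log units; beyond the scatter). For the compounds shown here, compound 2 also carries this chloro but differs from compound 1 in a second place, so only this pair shows the change on its own. The full size of the step remains unknown, since the value of compound 1 is a limit and not a number: the limit of > 100000 nM in this assay, at which 1 of the 3 values shown sits.

The compounds shown leave open whether an amine or a methoxy group on this carbon would lower the number as well. They also do not show what lies behind the step.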